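The source may report more compounds than this note shows. Statements on the series, on what has been measured and on what is new or still open speak of the compounds shown alone.

Compound 2 `COc1cc(-c2nn(-c3cccc(NC(=O)Nc4ccc(Cl)c(Cl)c4)c3)cc2-c2ccncc2)ccc1Cl` stands second highest of the three numbers in a functional assay on SK-MEL-5 cells (Homo sapiens) for inhibition, read by sulforhodamine B assay, with a stated time of 48 h; a higher number here means a weaker inhibitor of growth, a lower number a stronger inhibitor of growth: compound 2 gives 1490 nM, compound 3 `O=C(Nc1cccc(-n2cc(-c3ccncc3)c(-c3ccc(Cl)c(O)c3)n2)c1)Nc1ccc(Cl)c(Cl)c1` gives 1160 nM, and compound 1 `O=C(Nc1cccc(-n2cc(-c3ccncc3)c(-c3ccc(Cl)c(O)c3)n2)c1)Nc1cccc(C(F)(F)F)c1` gives 4710 nM. The step of a 1.3-fold lower number from compound 2 to compound 3 (0.11 log units; within the scatter) is within the scatter, so compound 2 and compound 3 cannot be ordered; the step of a 4.1-fold lower number from compound 1 to compound 3 (0.61 log units; beyond the scatter) is beyond it. Compound 4 `COc1cc(-c2nn(-c3cccc(NC(=O)Nc4ccc(Cl)c(C(F)(F)F)c4)c3)cc2-c2ccncc2)ccc1Cl` differs from compound 2 by trifluoromethyl in place of chloro on an aromatic carbon, on an aromatic carbon of a six-membered aromatic ring of carbon only, ortho to a chloro group and meta to a large group. For the measured compounds named here, the only measured step on this ring is a 4.1-fold lower number from compound 1 to compound 3 (0.61 log units; beyond the scatter), in which a trifluoromethyl and a chloro moved at once, so it bears on the present change only loosely; it suggests the trifluoromethyl-bearing ring gives the higher number. Going by the values given here, no measured step keeps the chloro while exchanging the other group. A modest step toward a higher number, or none beyond the scatter, is therefore expected, a 1.5-fold higher number from compound 2 to compound 4 (0.17 log units; within the scatter). Compound 4 is estimated at 2200 nM, with a range from 900 nM to 5500 nM.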

Compound 4, concentration for total growth inhibition: 2890 nM
For compound 4 the middle estimate is 1.3-fold (0.12 log units) below the measured one; low and high end bracket the measured number.
By their numbers in this assay, from the lowest: compounds 3, 2, 4 and 1 (each within the scatter of the next, the first and the last beyond it).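

In this assay, trifluoromethyl in place of chloro on this aromatic carbon, ortho to a chloro group, gives a 1.9-fold higher number from compound 2 to compound 4 (0.29 log units; within the scatter), so the exchange, taken alone with the chloro kept, cannot be ordered and this carbon carries either group without a step beyond the scatter. The earlier 4.1-fold lower number from compound 1 to compound 3 (0.61 log units; beyond the scatter) is beyond the scatter, but it changes two groups at once, and the present result does not show that the trifluoromethyl exchange alone accounts for it. Nothing measured here offers a reason for either step.

Open, going by these compounds, is what a nitrile, a methoxy or a methyl would give on this aromatic carbon. Also open, on these data alone, is how the same exchange reads with hydrogen in place of methyl on the oxygen.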